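Two aryl hydrazones of a piperidinone carbamate, and a dinitro analogue

The compounds below may be only part of what the source reports. "The series", "measured", "known", "first", "only" and "open" are said of these compounds alone.

Compound 1 `CCOC(=O)N1CCC(=NNC(=O)c2ccc(F)cc2)CC1` in a functional assay on A549 cells (Homo sapiens) for cytotoxicity, read by MTT assay, with a stated time of 24 h (on this read-out higher numbers stand for weaker inhibition and lower numbers for stronger inhibition), gives > 400000 nM, which is a limit of the assay and not a number.
Compound 2 `CCOC(=O)N1CCC(=NNC(=O)c2ccc([N+](=O)[O-])cc2)CC1` in this assay gives > 400000 nM, also a limit of the assay.

Among the measured compounds shown here, compound 2 therefore stands at the ceiling of what this assay reports: its result is a limit only, and the same holds for the one other value shown, so no ordering of the two can be read. For the measured compounds named here, the only measured step, a step that the two limits leave unreadable from compound 1 to compound 2, is likewise unreadable, since both ends are limits; the sole evidence is the limit of > 400000 nM in this assay, at which 2 of the 2 values shown sit.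

Compound 3 `CCOC(=O)N1CCC(=NNC(=O)c2ccc([N+](=O)[O-])cc2[N+](=O)[O-])CC1` differs from compound 2 by nitro in place of hydrogen on an aromatic carbon, in words nitro in place of hydrogen on an aromatic carbon. Going by the values given here, no measured step bears on this change in a readable way. Among the compounds with values here, with both neighbours at the limit and no step of any known size to go by, the expected step of a number no higher from compound 2 to compound 3 (the limit leaves the size open) is none beyond the scatter. Compound 3 is accordingly estimated at 400000 nM in this assay, within 100000 nM to 2000000 nM, most probably reported again as a limit.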

Compound 3, half-maximal inhibitory concentration: 27300000 nM
Beside the measured number, compound 3's estimate is 68-fold (1.83 log units) below it; the whole stated range lies below it.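

Among the compounds shown here, compound 2 has only a limit of the assay and not a number in this assay, so no step to compound 3 can be read, although compound 3 gives a number: the limit of > 400000 nM in this assay, at which 2 of the 3 values shown sit. The compounds shown leave open how far nitro in place of hydrogen on an aromatic carbon changes cytotoxicity, and whether compound 1 and compound 2 differ at all.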